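Trimming a Chain on a Ring-Bound Amide

A few compounds are considered here, and "the series" means these few. Any claim that something is new, unique, unknown or untested is made for them only; others in the source may bear on it.

Compound 1 `C/C=C/C(=O)Nc1ccc(Cn2nc(-c3ccc(Oc4ccccc4)cc3)cc2CO)cc1` gives 54500 nM in a functional assay on Z-138 cells (Homo sapiens) for inhibition, read by luminescence and CellTiter-Glo, with a stated time of 72 h; a higher number here means a weaker inhibitor, a lower number a stronger inhibitor.
Compound 2 `C=CC(=O)Nc1ccc(Cn2nc(-c3ccc(Oc4ccccc4)cc3)cc2CO)cc1` gives 6800 nM in this assay.
Compound 3 `C/C=C/C(=O)N1CCCC(n2nc(-c3ccc(Oc4ccccc4)cc3)cc2CO)C1` gives 51100 nM in this assay.

Compound 1 and compound 2 share one core and differ in a single place: vinyl in place of prop-1-en-1-yl on a carbonyl carbon. That change gave an 8.0-fold lower number from compound 1 to compound 2 (0.90 log units; beyond the scatter). Compound 3 carries another core; how its core differs from the core of compound 1 is not broken down here. Compound 3 and compound 1 give numbers within the scatter of each other.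

Compound 4 `C=CC(=O)N1CCCC(n2nc(-c3ccc(Oc4ccccc4)cc3)cc2CO)C1` has not yet been measured. It differs from compound 3 in one place: vinyl in place of prop-1-en-1-yl on a carbonyl carbon. The surroundings are not identical, though: in compound 3 the carbonyl carbon's other neighbour is an amide-type nitrogen in a ring, whereas in compound 1 it is an amide-type nitrogen, so this is the same kind of change, not the same change. In this assay, among the compounds with values here, the estimated step is a 6.4-fold lower number from compound 3 to compound 4 (0.81 log units; beyond the scatter), resting on the one comparable step seen because an 8.0-fold lower number from compound 1 to compound 2 (0.90 log units; beyond the scatter) is the only such change measured. The range is kept wide: the core differs. For compound 4 the estimate in this assay is 8000 nM, likely between 3000 nM and 25000 nM.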

Compound 4, half-maximal inhibitory concentration: 14600 nM
For compound 4 the middle estimate is 1.8-fold (0.26 log units) below the measured one; low and high end bracket the measured number.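

In this assay, putting vinyl in place of prop-1-en-1-yl on the carbonyl carbon gave a 3.5-fold lower number from compound 3 to compound 4 (0.54 log units; beyond the scatter). The change therefore points the same way on both cores, and the two steps are close enough in size to count as one repeated effect rather than two different ones: the same change on two cores in this assay, an 8.0-fold lower number (0.90 log units; beyond the scatter) from compound 1 to compound 2 and a 3.5-fold lower number (0.54 log units; beyond the scatter) from compound 3 to compound 4, 2.3-fold (0.36 log units) apart, within the scatter of two such steps. Within the data shown here, this is still only two pairs of compounds, so it supports carrying the change from the core of compound 1 to the core of compound 3, but it does not show that the change would hold on a third core, and it does not explain why the vinyl compounds give the lower numbers.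

The compounds shown leave open what other groups on this carbonyl carbon would do, such as a saturated ethyl chain, a longer chain or a dimethylamino-bearing butenyl chain. They also leave open whether the same step would appear on other cores or in any read-out other than this assay.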